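From 4-(Methylcarbamoyl)phenyl to 4-Hydroxy-3-methylphenyl

The source may report more compounds than this note shows. Statements on the series, on what has been measured and on what is new or still open speak of the compounds shown alone.

Of the compounds shown here, two on a shared core have so far been tested in an ADME assay on C8166 cells (Homo sapiens) for cytotoxicity (on this read-out higher numbers stand for lower toxicity in this test and lower numbers for higher toxicity in this test), and give only one true number between them. Compound 1 (`CCN1C(=O)N(c2ccccc2)C(=O)N(c2ccccc2)c2cc(C(F)(F)F)ccc21`) gives > 4000 nM there, which is a limit and not a number. Compound 2 (`CCN1C(=O)N(c2ccc(C(=O)NC)cc2)C(=O)N(c2ccccc2)c2cc(C(F)(F)F)ccc21`) gives 31000 nM in this assay and so stands alone, with no second number to be ranked against. Going by the values given here, the one measured step, a step that the limit leaves unreadable from compound 1 to compound 2, has no readable size, and the evidence on it is the limit of > 4000 nM in this assay, at which 1 of the 2 values shown sits, here.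

Compound 3 (`CCN1C(=O)N(c2ccc(O)c(C)c2)C(=O)N(c2ccccc2)c2cc(C(F)(F)F)ccc21`) keeps the core and carries 4-hydroxy-3-methylphenyl in place of 4-(methylcarbamoyl)phenyl on an amide-type nitrogen in a ring. Among the compounds with values here, since the step to compound 2, a step that the limit leaves unreadable from compound 1 to compound 2, gives no size to carry over, the only anchor is compound 2 at 31000 nM and no change beyond the usual scatter is expected. The expected move, a 1.4-fold lower number from compound 2 to compound 3 (0.15 log units; within the scatter), is small and leans slightly toward lower numbers. The estimate for compound 3 is 22000 nM in this assay, expected to lie between 6000 nM and 70000 nM at this stage.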

Compound 3, half-maximal cytotoxic concentration: 17000 nM
The estimate for compound 3 lay 1.3-fold (0.11 log units) above the measured number; low and high end bracket the measured number.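

In this assay, placing 4-hydroxy-3-methylphenyl in place of 4-(methylcarbamoyl)phenyl on the amide-type nitrogen in a ring gives a 1.8-fold lower number from compound 2 to compound 3 (0.26 log units; within the scatter). Going by these compounds alone, this is the first comparison at this position that rests on two true numbers, and it shows that two groups with different atoms can sit there without the read-out telling them apart: the group that leaves has a nitrogen and a double bond outside its aromatic ring, the group that enters has neither, and the two match in their counts of hydrogen-bond donors and acceptors. The steps that start from compound 1 cannot be read, so the plain phenyl group of compound 1 still cannot be placed against either substituted ring: the limit of > 4000 nM in this assay, at which 1 of the 3 values shown sits.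

Going by these compounds, what stays open is whether this tolerance holds for aromatic rings carrying quite different groups, such as a carboxylic acid or a dimethylamino group, or for a saturated ring such as cyclohexyl on the same nitrogen. The compounds shown also leave open how the hydroxy and methyl groups of compound 3 would each read alone, and whether the phenyl group elsewhere on the shared core would accept the same exchange.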